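Replacing the furoyl ester of compound 3 by a methanesulfonamide

The source may report more compounds than this note shows. Statements on the series, on what has been measured and on what is new or still open speak of the compounds shown alone.

Three compounds share one core and differ only in the group on a saturated ring carbon. Compound 1 `NC1CCC(CN2CCN(c3cc(=O)c4cc(C(F)(F)F)cc([N+](=O)[O-])c4s3)CC2)CC1` carries an amino group there; in an ADME assay on cells (Hepatocyte, Homo sapiens) for metabolic stability, with a stated time of 30 min (a lower number here means that less of the compound is left, a higher number that more of the compound is left), compound 1 gives 83.6%. Compound 2 `O=C(OC1CCC(CN2CCN(c3cc(=O)c4cc(C(F)(F)F)cc([N+](=O)[O-])c4s3)CC2)CC1)C1CCCCC1` carries a (cyclohexylcarbonyl)oxy group, and compound 2 gives 2.8%. Compound 3 `O=C(OC1CCC(CN2CCN(c3cc(=O)c4cc(C(F)(F)F)cc([N+](=O)[O-])c4s3)CC2)CC1)c1ccco1` carries a ((furan-2-yl)carbonyl)oxy group, and compound 3 gives 1%. Compound 3 thus stands lowest of the three; the gap to compound 2 is within the scatter, a number 1.8 percentage points lower from compound 2 to compound 3 (within the scatter), while the gap to compound 1 is large, a number 82.6 percentage points lower from compound 1 to compound 3 (beyond the scatter).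

Compound 4 `CS(=O)(=O)NC1CCC(CN2CCN(c3cc(=O)c4cc(C(F)(F)F)cc([N+](=O)[O-])c4s3)CC2)CC1` is not yet measured. It differs from compound 3 as follows: methanesulfonamido in place of ((furan-2-yl)carbonyl)oxy on a saturated ring carbon. Within the data shown here, the steps that bear on this change are those leaving the amino group of compound 1, a number 80.8 percentage points lower from compound 1 to compound 2 (beyond the scatter) and a number 82.6 percentage points lower from compound 1 to compound 3 (beyond the scatter), both large downward. The change to compound 4 removes the ((furan-2-yl)carbonyl)oxy group again, so a large step upward is expected, a number 69 percentage points higher from compound 3 to compound 4 (beyond the scatter), back toward the level of compound 1. Among the measured compounds shown here, no step from an amino group to a methanesulfonamido group is available, so the expectation is not anchored beyond compound 1. Compound 4 is estimated at 70%, with a range from 40% to 95%.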

Compound 4, percent of the compound remaining: 105%
Beside the measured number, compound 4's estimate is 35 percentage points below it; measured number outside the range, above it.
By their numbers in this assay, from the lowest: compounds 3 and 2 (each within the scatter of the next); then compound 1; then compound 4.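

Going from either ester to the methanesulfonamide reverses the loss seen at this saturated ring carbon in this assay, with a number 104 percentage points higher from compound 3 to compound 4 (beyond the scatter) and a number 102.2 percentage points higher from compound 2 to compound 4 (beyond the scatter), so the low numbers of compound 2 and compound 3 do not extend to every group that replaces amino there. Nor is the free amino group the ceiling at this position: methylsulfonyl in place of hydrogen on the amine nitrogen gives a number 21.4 percentage points higher from compound 1 to compound 4 (beyond the scatter), a modest step, and this places compound 4 highest of the four compounds, with its steps to all three others beyond the scatter. The data at hand offer no measurement that explains these differences.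

As far as these compounds go, it remains open whether the low numbers follow the ester linkage itself or the acyl groups it carries, a question that an amide bearing cyclohexylcarbonyl or (furan-2-yl)carbonyl on the same nitrogen would address. From the compounds shown here alone, it also remains open whether the high number is particular to methanesulfonamido or would hold for an ethylsulfonyl group, a phenylsulfonyl group or an acetamide at this ring carbon.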